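The source may report more compounds than this note shows. Statements on the series, on what has been measured and on what is new or still open speak of the compounds shown alone.

Compound 1 `C=C1CC[C@@H]2[C@](C)(COC(C)=O)[C@H](OC(C)=O)CC[C@@]2(C)[C@H]1CC(Nc1ccc(S(=O)(=O)Nc2ccc(Cl)nn2)cc1)C1=CCOC1=O`, compound 2 `C=C1CC[C@@H]2[C@](C)(COC(C)=O)[C@H](OC(C)=O)CC[C@@]2(C)[C@H]1CC(Nc1ccc(S(=O)(=O)Nc2cc(C)on2)cc1)C1=CCOC1=O` and compound 3 `C=C1CC[C@@H]2[C@](C)(COC(C)=O)[C@H](OC(C)=O)CC[C@@]2(C)[C@H]1CC(Nc1ccc(S(=O)(=O)Nc2ncccn2)cc1)C1=CCOC1=O` share one core and differ only in the group on the sulfonamide nitrogen. In a functional assay on K562 cells (Homo sapiens) for inhibition, read by sulforhodamine B assay, with a stated time of 48 h (a lower number here means that less compound is tolerated, a higher number that more compound is tolerated), compound 1 gives only a limit, > 100000 nM. In this assay compound 2 likewise gives a limit, > 100000 nM. Compound 3 also reaches only a limit, > 100000 nM. The steps a step that the two limits leave unreadable from compound 1 to compound 2, a step that the two limits leave unreadable from compound 1 to compound 3 and a step that the two limits leave unreadable from compound 2 to compound 3 are unreadable, and compound 3 stands with the other two at the limit of > 100000 nM in this assay, at which 3 of the 3 values shown sit. Compound 4 `C=C1CC[C@@H]2[C@](C)(COC(C)=O)[C@H](OC(C)=O)CC[C@@]2(C)[C@H]1CC(Nc1ccc(S(=O)(=O)Nc2nccs2)cc1)C1=CCOC1=O` carries the change (1,3-thiazol-2-yl in place of pyrimidin-2-yl on a sulfonamide nitrogen). For the measured compounds named here, no measured step gives a readable size for this exchange, and the three unreadable steps give no direction. The step of a number no higher from compound 3 to compound 4 (the limit leaves the size open) is expected to stay within the scatter. Compound 4 is expected at 100000 nM, between 50000 nM and 300000 nM, most likely again a limit.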

Compound 4, concentration lethal to 50% of the cells: > 100000 nM
Compound 4 was reported as a limit (the forecaster's own chance of this, stated with the estimate: 85%); the middle value sits exactly at the limit.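

Compound 4, like compound 1, compound 2 and compound 3, gives only a limit in this assay, so no step among them can be read: the limit of > 100000 nM in this assay, at which 4 of the 4 values shown sit.

The compounds shown leave open whether exchanging the group on the sulfonamide nitrogen changes the read-out at all.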